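Taking the methoxy off compound 3

The source may report more compounds than this note shows. Statements on the series, on what has been measured and on what is new or still open speak of the compounds shown alone.

Measured so far in a functional assay on HeLa cells (Homo sapiens) for antiproliferative activity, read by MTT assay, with a stated time of 48 h; a lower number here means a stronger inhibitor, a higher number a weaker inhibitor:
compound 1 `COc1ccc2nc(NC(c3cn(-c4ccccc4)nc3-c3ccc([N+](=O)[O-])cc3)c3c(O)ccc4ccccc34)sc2c1`: 5540 nM
compound 2 `COc1ccc(-c2nn(-c3ccccc3)cc2C(Nc2nc3ccc(OC)cc3s2)c2c(O)ccc3ccccc23)cc1`: 9240 nM
compound 3 `COc1cccc(-c2nn(-c3ccccc3)cc2C(Nc2nc3ccc(OC)cc3s2)c2c(O)ccc3ccccc23)c1`: 10500 nM

Compound 3 gives 10500 nM and is not separated from the other two compounds. Two steps reach it, a 1.1-fold higher number from compound 2 to compound 3 (0.06 log units; within the scatter) and a 1.9-fold higher number from compound 1 to compound 3 (0.28 log units; within the scatter), and both stay within the usual scatter.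

Compound 4 `COc1ccc2nc(NC(c3cn(-c4ccccc4)nc3-c3ccccc3)c3c(O)ccc4ccccc34)sc2c1` carries hydrogen in place of methoxy on an aromatic carbon, meta to a large group, and the counted difference is hydrogen in place of methoxy on an aromatic carbon. The same difference reads 3-methoxyphenyl to phenyl. Among the compounds with values here, no measured step removes a group from this ring outright, so the change has no direct precedent. The nearest evidence is the set of exchanges on the same ring, which also includes a 1.7-fold higher number from compound 1 to compound 2 (0.22 log units; within the scatter) as well as the two steps above. Within the data shown here, all three are small, though they rest on only three compounds.

No step beyond the scatter is therefore expected in this assay, in either direction. The expected step is a 1.3-fold lower number from compound 3 to compound 4 (0.12 log units; within the scatter) as a working figure only. For compound 4 the estimate is 8000 nM, with an expected range of 4000 nM to 16000 nM as the outcome.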

Compound 4, half-maximal inhibitory concentration: 8290 nM
The estimate for compound 4 lay 1.0-fold (0.02 log units) below the measured number; low and high end bracket the measured number.
By their numbers in this assay, from the lowest: compounds 1, 4, 2 and 3 (each within the scatter of the next).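

Compound 3 loses its methoxy outright in this assay with a 1.3-fold lower number from compound 3 to compound 4 (0.10 log units; within the scatter) and no separation from the parent, and the same exchange read from the other methoxy compound gives a 1.1-fold lower number from compound 2 to compound 4 (0.05 log units; within the scatter) with the same outcome. Hydrogen in place of nitro gives a 1.5-fold higher number from compound 1 to compound 4 (0.18 log units; within the scatter) and again stays within the scatter, so the unsubstituted phenyl now serves as a reference point that the earlier group-for-group exchanges could not supply, and neither methoxy nor nitro on this ring separates from it. No measurement is at hand that would explain this flat reading.
As far as these compounds go, whether this ring stays as flat with an amine, a carboxylic acid or a longer chain such as butoxy in place of hydrogen remains open, as the four compounds carry only methoxy, nitro or hydrogen there. Also open, from the compounds shown here alone, is whether changes elsewhere on the shared core, such as to its other methoxy or its hydroxyl, would produce a step beyond the scatter in this assay at all.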